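A few compounds are considered here, and "the series" means these few. Any claim that something is new, unique, unknown or untested is made for them only; others in the source may bear on it.

In an ADME assay on the whole organism (Rattus norvegicus) for metabolic stability, at a dose of 0.5 mg/kg by the intravenous route (on this read-out higher numbers stand for a longer-lived compound and lower numbers for a shorter-lived compound), compound 1 `COc1cc(OCc2csc(-c3ccc(C(F)(F)F)cc3)n2)c2cc(-c3cn4nc(OC)sc4n3)oc2c1` gives 31 h and compound 2 `COc1cc(OCc2cccc(-c3cnc(OC)nc3)c2)c2cc(-c3cn4nc(OC)sc4n3)oc2c1` gives 40 h as its half-life. These two values lie within the usual scatter of each other, so compound 2 stands level with compound 1. Compound 3 `COc1ccc(-c2cccc(COc3cc(OC)cc4oc(-c5cn6nc(OC)sc6n5)cc34)c2)nc1` is still unmeasured and differs from compound 2 in one place, with 5-methoxypyridin-2-yl in place of 2-methoxypyrimidin-5-yl on an aromatic carbon and nothing else altered. Going by the values given here, no measured pair shows what a change of this kind does, so the value of compound 2 at 40 h is the natural starting point. No step beyond the scatter is expected in this assay in either direction, and the estimated step of a 1.3-fold lower number from compound 2 to compound 3 (0.12 log units; within the scatter) is small. Compound 3 is estimated at 30 h with 14 h to 60 h as the expected range.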

Compound 3, half-life: 110 h
Compound 3: middle estimate off by 3.7-fold (0.56 log units), on the low side, and the stated range ends below it.
By their numbers in this assay, from the lowest: compounds 1 and 2 (each within the scatter of the next); then compound 3.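

Within this assay, this spot on the carbon-only aromatic ring responds to the choice of methoxy-bearing ring: putting 5-methoxypyridin-2-yl in place of 2-methoxypyrimidin-5-yl gives a 2.8-fold higher number from compound 2 to compound 3 (0.44 log units; beyond the scatter). The two groups have the same count of heavy atoms, and the entering ring holds one hetero atom fewer, so a swap that leaves group size unchanged is enough to move the half-life beyond the scatter. Nothing available explains how this swap lengthens the half-life.

The two rings also differ in how the methoxy group and the attachment point are arranged, so this one pair cannot separate the loss of a ring nitrogen from that rearrangement. It also leaves open how a plain methoxyphenyl ring would behave here, or a pyridine ring carrying an amine or a carboxylic acid instead of methoxy.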